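The source may hold more compounds than are shown below. What is called first, only, known or untested is meant among the compounds shown, and "the series" means these compounds.

Measured compounds:
- compound 2, `COc1ccc(F)cc1N1C(=O)CSC1c1cccc(C(=O)NCCCCc2ccccc2)c1` — 8.8 nM
- compound 1, `COc1ccc(F)cc1N1C(=O)CSC1c1cccc(C(=O)NCCCCn2cccn2)c1` — 97.3 nM
- compound 3, `O=C(NCCCc1ccccc1)c1cccc(C2SCC(=O)N2c2ccc(C3CC3)cc2)c1` — limit only

In a functional assay on HOS-TE85 cells (Homo sapiens) for inhibition, read by CCK-8 assay, with a stated time of 72 h (on this read-out lower numbers stand for stronger inhibition and higher numbers for weaker inhibition), compound 2 gives 8.8 nM, the lowest of the two numbers shown; compound 1 gives 97.3 nM and is the nearest. Going by the values given here, the only measured step, an 11-fold lower number from compound 1 to compound 2 (1.04 log units; beyond the scatter), concerns phenyl in place of 1H-pyrazol-1-yl on a saturated chain carbon, four bonds along the chain from an amide-type nitrogen, and does not touch the ring nitrogen varied here. Compound 3, which carries a different aryl on that nitrogen and a shorter chain, returns only a limit, > 1000 nM. The third value thus sits at the limit of > 1000 nM in this assay, at which 1 of the 3 values shown sits.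

The unmeasured compound 4, `O=C(NCCCCc1ccccc1)c1cccc(C2SCC(=O)N2c2nccs2)c1`, differs from compound 2 by 1,3-thiazol-2-yl in place of 5-fluoro-2-methoxyphenyl on an amide-type nitrogen in a ring. Among the compounds with values here, no measured step bears on this change, so direction and size cannot be read from the series; a wide range is warranted. Compound 4 is estimated at 60 nM, with a range from 12 nM to 400 nM. The expected step, a 6.8-fold higher number from compound 2 to compound 4 (0.83 log units; beyond the scatter), would be a weakening, but the data give no firm ground for it.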

Compound 4, half-maximal inhibitory concentration: > 1000 nM
Compound 4 ended at the assay's limit; the forecaster's own chance of this, stated with the estimate: 15%; at least 16-fold (1.22 log units) between middle value and limit.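

With the rest of compound 2 unchanged, the group on the amide-type ring nitrogen alone accounts for the change in this assay, which is an at least 110-fold higher number from compound 2 to compound 4 (2.05 log units; beyond the scatter) and shows that activity here depends strongly on this group. Compound 3 had changed this group together with the chain, so it could not separate the two. On these data alone, compound 4 stands at a limit, not at a number, so the full size of the step is unknown: the limit of > 1000 nM in this assay, at which 2 of the 4 values shown sit.

The compounds shown leave open whether the 5-fluoro-2-methoxyphenyl group matters through its fluorine, its methoxy group or its six-membered aromatic ring of carbon only. Plain phenyl, 2-methoxyphenyl and pyridin-2-yl on this nitrogen would be needed to tell these apart, and whether any other five-membered aromatic ring is tolerated here also remains open.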